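The compounds below may be only part of what the source reports. "The series", "measured", "known", "first", "only" and "open" are said of these compounds alone.

Going by the values given here, in a functional assay on MIA PaCa-2 cells (Homo sapiens) for inhibition, read by MTT assay, with a stated time of 48 h, tested at 10 uM (a higher number here means more inhibition of growth at the concentration tested, a lower number less inhibition of growth), compound 1 `Cc1cc(=O)c2c(O)c(CN3CCCC3)c(O)c([C@H]3CCN(C)C[C@H]3O)c2o1` gives 28% and compound 2 `Cc1cc(=O)c2c(O)c(CN(C)CC(=O)O)c(O)c([C@H]3CCN(C)C[C@H]3O)c2o1` gives 16%, so compound 2 holds the lower of the two numbers so far. The next change leads to compound 3 `Cc1cc(=O)c2c(O)c(CN(C(C)C)C(C)C)c(O)c([C@H]3CCN(C)C[C@H]3O)c2o1`: diisopropylamino in place of (carboxymethyl)(methyl)amino on a saturated chain carbon bound to an aromatic carbon. It falls on the same saturated chain carbon bound to an aromatic carbon. Among the compounds with values here, one measured step bears on it, at that same place: a number 12 percentage points lower from compound 1 to compound 2 (beyond the scatter), a modest step beyond the scatter, made by bringing in (carboxymethyl)(methyl)amino in place of pyrrolidin-1-yl. Within the data shown here, compound 3 gives that group up again, though for diisopropylamino rather than pyrrolidin-1-yl, and no measured compound carries diisopropylamino. A modest rise of similar size is therefore expected, a number 11 percentage points higher from compound 2 to compound 3 (beyond the scatter). The estimate for compound 3 is 27%, with an expected range of 14% to 42%.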

Compound 3, percent growth inhibition at one concentration: 11%
The estimate for compound 3 lay 16 percentage points above the measured number, outside the stated range (below it).
By their numbers in this assay, from the lowest: compounds 3 and 2 (each within the scatter of the next); then compound 1.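

At the saturated chain carbon bound to an aromatic carbon, replacing (carboxymethyl)(methyl)amino with diisopropylamino does not separate the two compounds in this assay (a number 5 percentage points lower from compound 2 to compound 3 (within the scatter)). The step away from pyrrolidin-1-yl is beyond the scatter with diisopropylamino as well (a number 17 percentage points lower from compound 1 to compound 3 (beyond the scatter)), so among these three compounds, compound 1 alone stands apart, and a second open-chain amino group without the carboxylic acid does not rejoin it. No information on the reason for this separation is at hand.

Still open, going by these compounds, is whether a piperidine, a morpholine or a plain dimethylamino group on this carbon would sit with compound 1 or with compound 3. Also open, on these data alone, is whether pyrrolidin-1-yl holds its place when the ring is opened to a diethylamino group.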